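Adding Methyl to the Chain of Compound 2

This account rests on a few compounds, and the source may have more. Where it says the series, first, only, none or still open, it means among the compounds named here.

In a physicochemical assay for lipophilicity, read by HPLC, with a stated time of 30 min (a lower number here means a more polar compound, a higher number a more lipophilic compound), compound 1 `CCC[C@](C)(CO)Nc1nc(N)nc2cccnc12` gives 1.1 and compound 2 `CCCCC[C@](C)(CO)Nc1nc(N)nc2cccnc12` gives 1.8 as the higher of the two numbers. Compound 3 `CCCCCC[C@](C)(CO)Nc1nc(N)nc2cccnc12` differs from compound 2 by methyl in place of hydrogen on a saturated chain carbon, six bonds along the chain from a nitrogen on an aromatic ring. For the measured compounds named here, the one measured step that bears on this put ethyl in place of hydrogen on the same chain and gave a modest rise (a number 0.70 log units higher from compound 1 to compound 2 (beyond the scatter)) beyond the scatter. With only methyl entering, a rise of smaller size in this assay is expected (a number 0.40 log units higher from compound 2 to compound 3 (beyond the scatter)) for this change. For compound 3 the estimated value is 2.2 with an expected range from 1.9 to 2.5 for now.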

Compound 3, distribution coefficient: 2.5
Estimate against measurement, compound 3: 0.30 log units below, within the range that was stated.
By their numbers in this assay, from the lowest: compound 1; then compound 2; then compound 3.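

In this assay the added methyl gives a number 0.70 log units higher from compound 2 to compound 3 (beyond the scatter) and so matches the earlier ethyl step in size: a smaller group did not bring a smaller rise at this position. Over the whole change, the chain gives a number 1.40 log units higher from compound 1 to compound 3 (beyond the scatter) and the number climbs with each lengthening among these three compounds. No measurement here explains this climb.

From the compounds shown here alone, whether the rise continues with a longer chain remains open. So does what an amine or a carboxylic acid would do to the number in place of this methyl.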